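The source may report more compounds than this note shows. Statements on the series, on what has been measured and on what is new or still open speak of the compounds shown alone.

Values in a functional assay on RAW264.7 cells (Mus musculus) for inhibition; on this read-out lower numbers stand for stronger inhibition and higher numbers for weaker inhibition:

- Compound 1 `CCOC(=O)C1=CCCCC1S(=O)(=O)Nc1ccccc1` gives 260 nM
- Compound 2 `CCOC(=O)C1=CCCCC1S(=O)(=O)Nc1cccc(F)c1` gives 150 nM
- Compound 3 `CCOC(=O)C1=CCCCC1S(=O)(=O)Nc1ccc(Cl)cc1` gives 400 nM

The position of compound 3 shows in two steps: a 1.5-fold higher number from compound 1 to compound 3 (0.19 log units; within the scatter) and a 2.7-fold higher number from compound 2 to compound 3 (0.43 log units; beyond the scatter). Only compound 2 is therefore clearly separated from it.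

The next compound, compound 4 `CCOC(=O)C1=CCCCC1S(=O)(=O)Nc1nccs1`, carries 1,3-thiazol-2-yl in place of 4-chlorophenyl on a sulfonamide nitrogen.

The measured steps offer limited guidance. Two are small swaps of a single substituent, a 1.7-fold lower number from compound 1 to compound 2 (0.24 log units; within the scatter) and a 1.5-fold higher number from compound 1 to compound 3 (0.19 log units; within the scatter), and the third is the modest 2.7-fold higher number from compound 2 to compound 3 (0.43 log units; beyond the scatter). All three compounds keep an aromatic ring of carbon only, so no measurement covers replacing that ring. The change is larger than any of these steps, so a step beyond the scatter seems likely, though its direction is uncertain. A higher number is the cautious expectation, and the range must stay wide.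

The expected change in this assay is a 1.8-fold higher number from compound 3 to compound 4 (0.24 log units; within the scatter).

Compound 4 is estimated at 700 nM, with an expected range from 200 nM to 3000 nM.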

Compound 4, half-maximal inhibitory concentration: > 10000 nM
Compound 4: no number, only a limit; the forecaster's own chance of this, stated with the estimate: 10%; middle value at least 14-fold (1.15 log units) away from the limit.
By their numbers in this assay, from the lowest: compounds 2, 1 and 3 (each within the scatter of the next, the first and the last beyond it). At a limit, above all of these: compound 4.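

Compound 4 gives only a limit of the assay, not a number: the limit of > 10000 nM in this assay, at which 1 of the 4 values shown sits.

In this assay, placing 1,3-thiazol-2-yl on the sulfonamide nitrogen gives an at least 25-fold higher number from compound 3 to compound 4 (1.39 log units; beyond the scatter), an at least 38-fold higher number from compound 1 to compound 4 (1.58 log units; beyond the scatter) and an at least 66-fold higher number from compound 2 to compound 4 (1.82 log units; beyond the scatter). The earlier compounds shown here varied only a fluoro or chloro substituent on an aromatic ring of carbon only, so they could not show what this new result shows: among the four compounds, the identity of the ring itself at this position matters far more than those substituents do.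

The compounds shown leave open whether another ring on this nitrogen, such as pyridin-2-yl, would keep the inhibition or whether only a ring of carbon alone does. They also leave open how far past the limit the true value of compound 4 lies.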